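Quinolin-2-yl Replaces Pyridin-4-yl on the Ether Carbon

The source may hold more compounds than are shown below. What is called first, only, known or untested is meant among the compounds shown, and "the series" means these compounds.

Compound 1, `CC(c1ccc(OCc2ccccc2)cc1)N(O)C(=O)c1ccccc1`: 690 nM
Compound 2, `CCCCOc1ccc(C(C)N(O)C(=O)c2ccccc2)cc1`: 1300 nM
Compound 3, `CC(c1ccc(OCc2ccncc2)cc1)N(O)C(=O)c1ccccc1`: 2600 nM

Three compounds share one core and differ only in the group on a saturated chain carbon bound to an oxygen on an aromatic ring. In an assay on RBL-1 cells for inhibition of Polyunsaturated fatty acid 5-lipoxygenase (Rattus norvegicus) (a lower number here means a stronger inhibitor, a higher number a weaker inhibitor), compound 3 gives 2600 nM, the highest of the three numbers. Its distance from compound 1 is a 3.8-fold higher number from compound 1 to compound 3 (0.58 log units; beyond the scatter), a modest step beyond the scatter, whereas the step of a 2.0-fold higher number from compound 2 to compound 3 (0.30 log units; within the scatter) stays within the scatter, so compound 2 and compound 3 cannot be told apart here.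

Compound 4, `CC(c1ccc(OCc2ccc3ccccc3n2)cc1)N(O)C(=O)c1ccccc1`, carries quinolin-2-yl in place of pyridin-4-yl on a saturated chain carbon bound to an oxygen on an aromatic ring. Among the compounds with values here, no measured step involves a quinolin-2-yl group, so the only guidance comes from the two steps into compound 3: a 3.8-fold higher number from compound 1 to compound 3 (0.58 log units; beyond the scatter) and a 2.0-fold higher number from compound 2 to compound 3 (0.30 log units; within the scatter), both of which ended at the highest number. Quinolin-2-yl brings a six-membered aromatic ring of carbon only alongside the ring with one hetero atom, which makes it resemble the phenyl of compound 1 in one half. The author therefore expects compound 4 to return part of the way toward compound 1, an estimated step of a 2.6-fold lower number from compound 3 to compound 4 (0.41 log units; beyond the scatter). In this assay compound 4 is estimated at 1000 nM, within a range from 300 nM to 4000 nM.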

Compound 4, half-maximal inhibitory concentration: 400 nM
Beside the measured number, compound 4's estimate is 2.5-fold (0.40 log units) above it; measured number inside the range.
By their numbers in this assay, from the lowest: compounds 4, 1, 2 and 3 (each within the scatter of the next, the first and the last beyond it).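

At this place, on a saturated chain carbon bound to an oxygen on an aromatic ring, a ring with one hetero atom does not by itself go with a weak number: in this assay, quinolin-2-yl in place of pyridin-4-yl gives a 6.5-fold lower number from compound 3 to compound 4 (0.81 log units; beyond the scatter), the largest step in the set so far. Compound 3 could not be told apart from the propyl-bearing compound 2, but the quinolin-2-yl group separates clearly from propyl, with a 3.3-fold lower number from compound 2 to compound 4 (0.51 log units; beyond the scatter). Against phenyl the step is a 1.7-fold lower number from compound 1 to compound 4 (0.24 log units; within the scatter), so compound 1 and compound 4 cannot be told apart, and no measurement shown here accounts for any of these steps.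

The compounds shown do not tell whether the hetero atom of quinolin-2-yl matters or whether the second ring alone goes with the lower number, a question that a naphthalen-2-yl group at this place would address. They also leave open how pyridin-2-yl would compare with pyridin-4-yl, and so whether the gap between compound 3 and compound 1 depends on where the ring nitrogen sits.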